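The source may hold more compounds than are shown below. What is called first, only, known or untested is meant among the compounds shown, and "the series" means these compounds.

Measured in a functional assay on HL-60 cells (Homo sapiens) for antiproliferative activity, read by MTT assay, with a stated time of 72 h; on this read-out higher numbers stand for weaker inhibition and lower numbers for stronger inhibition:
compound 1, `N=C(NS(=O)(=O)c1ccccc1Cl)N1CCN(c2cc3c(cc2F)c(=O)c(C(=O)O)cn3C2CC2)CC1`, 43 nM
compound 2, `N=C(NS(=O)(=O)c1ccc(Cl)cc1)N1CCN(c2cc3c(cc2F)c(=O)c(C(=O)O)cn3C2CC2)CC1`, 43 nM
compound 3, `N=C(NS(=O)(=O)c1ccc(C(F)(F)F)cc1)N1CCN(c2cc3c(cc2F)c(=O)c(C(=O)O)cn3C2CC2)CC1`, 43 nM

All three share one core and differ only in the aryl group on the sulfonyl sulfur. Compound 3 stands level with compound 1 and compound 2 at the digits shown; none of the three is separated from another by more than the usual scatter.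

Compound 4 is `N=C(NS(=O)(=O)c1ccccc1C(F)(F)F)N1CCN(c2cc3c(cc2F)c(=O)c(C(=O)O)cn3C2CC2)CC1`. It has the same atoms as compound 3, joined differently: 2-(trifluoromethyl)phenyl in place of 4-(trifluoromethyl)phenyl on a sulfonyl sulfur

Going by the values given here, three measured steps bear on this. The closest in kind is the swap of one chlorophenyl for the other on the same sulfur, which gave no change at the digits printed from compound 1 to compound 2 (within the scatter). The exchange of chloro for trifluoromethyl gave no change at the digits printed from compound 2 to compound 3 (within the scatter), and the combined change gave no change at the digits printed from compound 1 to compound 3 (within the scatter). Each of these lay within the scatter, so moving the trifluoromethyl group from one place on the phenyl ring to another is expected to give no change at the digits printed from compound 3 to compound 4 (within the scatter), with no step beyond the scatter in either direction. Compound 4 is therefore estimated at 43 nM, in a range from 20 nM to 95 nM.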

Compound 4, half-maximal inhibitory concentration: 43 nM
Compound 4: middle estimate and measured number agree at the digits printed; the measured number falls inside the stated range.
By their numbers in this assay, from the lowest: compounds 1, 2, 3 and 4 (each within the scatter of the next).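

In this assay, moving the trifluoromethyl group gives no change at the digits printed from compound 3 to compound 4 (within the scatter), so the insensitivity to placement seen with the two chlorophenyl groups now extends to a second substituent on the ring attached to the sulfonyl sulfur. Replacing 4-chlorophenyl with 2-(trifluoromethyl)phenyl gives no change at the digits printed from compound 2 to compound 4 (within the scatter), so changing the substituent and its place together also leaves the number where it was. Exchanging chloro for trifluoromethyl, now with both groups in the other ring placement, gives no change at the digits printed from compound 1 to compound 4 (within the scatter), and the exchange reads the same in both placements: the same change on two cores in this assay, no change at the digits printed (within the scatter) from compound 2 to compound 3 and no change at the digits printed (within the scatter) from compound 1 to compound 4, 1.0-fold (0.00 log units) apart, within the scatter of two such steps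

Since all four compounds sit together, nothing here shows what change at this sulfur would move the number at all. On these data alone, whether an amine or a carboxylic acid on the phenyl ring, or a longer alkyl chain in place of that ring, would do so remains open.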